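The source may report more compounds than this note shows. Statements on the series, on what has been measured and on what is new or still open speak of the compounds shown alone.

Measured compounds in this set:
Compound 1 `CCn1c(C(=O)NCC(=O)OC)ccc1C(CC)(CC)c1ccc(OCS(=O)(=O)c2ccccc2)c(C)c1` gives 20000 nM in a functional assay on BXPC-3 cells (Homo sapiens) for antiproliferative activity, read by MTT assay, with a stated time of 24 h; on this read-out higher numbers stand for weaker inhibition and lower numbers for stronger inhibition.
Compound 2 `CCn1c(C(=O)N[C@H](C)C(=O)OC)ccc1C(CC)(CC)c1ccc(OCS(=O)(=O)c2ccccc2)c(C)c1` gives > 50000 nM, a limit of this assay rather than a number.
Compound 3 `CCn1c(C(=O)NCCC(=O)OC)ccc1C(CC)(CC)c1ccc(OCS(=O)(=O)c2ccccc2)c(C)c1` gives > 50000 nM, likewise a limit and not a number.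

Compound 3 therefore stands at the weak end of what this assay can report. Compound 4 `CCn1c(C(=O)NCCNC(=O)OC(C)(C)C)ccc1C(CC)(CC)c1ccc(OCS(=O)(=O)c2ccccc2)c(C)c1` differs from it by (tert-butoxycarbonyl)amino in place of methoxycarbonyl on a saturated chain carbon, two bonds along the chain from an amide-type nitrogen. Two measured steps on the same chain bear on this change: an at least 2.5-fold higher number from compound 1 to compound 2 (0.39 log units; beyond the scatter) and an at least 2.5-fold higher number from compound 1 to compound 3 (0.39 log units; beyond the scatter); the step that the two limits leave unreadable from compound 2 to compound 3 stays unreadable because the limit of > 50000 nM in this assay, at which 2 of the 3 values shown sit, holds both values. No change on this chain has yet brought a number back inside the assay window, so compound 4 is expected to remain at the limit, with a number no higher from compound 3 to compound 4 (the limit leaves the size open). For compound 4 the expected value is 50000 nM, within a range from 20000 nM to 100000 nM.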

Compound 4, half-maximal inhibitory concentration: > 50000 nM
Compound 4 ended at the assay's limit; the forecaster's own chance of this, stated with the estimate: 65%; the middle value lies on the limit itself.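

With (tert-butoxycarbonyl)amino in place of methoxycarbonyl, the chain no longer ends in an ester, yet this assay still returns no number: an at least 2.5-fold higher number from compound 1 to compound 4 (0.39 log units; beyond the scatter). Compound 4 gives > 50000 nM, which is a limit of the assay. The steps to compound 4 from compound 2 and from compound 3 cannot be read, so any difference among these compounds stays hidden: the limit of > 50000 nM in this assay, at which 3 of the 4 values shown sit.

On these data alone, whether a free amine or a carboxylic acid at the chain end would bring a number back inside the assay window remains open. A longer chain is equally untested among the compounds shown.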